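Swapping the Aryl Ring of Compound 1: Cytotoxicity Outlook

The source may hold more compounds than are shown below. What is called first, only, known or untested is meant among the compounds shown, and "the series" means these compounds.

Compound 1 `Cc1oc(-c2ccc(Cl)cc2)nc1CN1CCC(C(=O)NCCCN2C[C@H](C)C[C@H](C)C2)CC1` gives 11500 nM.
Compound 2 `Cc1ccccc1-c1nc(CN2CCC(C(=O)NCCCN3CCCC(CC(C)C)C3)CC2)c(C)o1` gives 4640 nM.
Compound 3 `Cc1ccccc1-c1nc(CN2CCC(C(=O)NCCN3C[C@H](C)C[C@H](C)C3)CC2)c(C)o1` gives 24400 nM.

These three numbers come from an ADME assay on Huh7.5.1 cells (Homo sapiens) for cytotoxicity, read by ATP content, with a stated time of 48 h; a lower number here means that less compound is tolerated, a higher number that more compound is tolerated. Among them compound 1 stands second highest: compound 3 lies a little above it, beyond the scatter, and compound 2 lies further below it, also beyond the scatter. Going by the values given here, the one step between compounds that differ in a single place is a 5.3-fold higher number from compound 2 to compound 3 (0.72 log units; beyond the scatter), and that step concerns the saturated ring at the far end of the chain, not the aromatic ring attached to the shared core.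

Compound 4 `COc1cccc(Br)c1-c1nc(CN2CCC(C(=O)NCCCN3C[C@H](C)C[C@H](C)C3)CC2)c(C)o1` differs from compound 1 only at that aromatic ring: 2-bromo-6-methoxyphenyl in place of 4-chlorophenyl on an aromatic carbon. Among the compounds with values here, no measured pair in this set changes the group on this position, so nothing here shows how the cytotoxicity responds to such a swap. What can be said is that all three measured compounds, which share the same sort of aromatic ring on the core, fall within a narrow band around the value of compound 1. The step from compound 1 to compound 4 is therefore expected to be small, a 1.0-fold lower number from compound 1 to compound 4 (0.02 log units; within the scatter), with no clear direction. Compound 4 is estimated at 11000 nM, within a range from 4000 nM to 30000 nM.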

Compound 4, half-maximal cytotoxic concentration: 14900 nM
Beside the measured number, compound 4's estimate is 1.4-fold (0.13 log units) below it, within the range that was stated.
By their numbers in this assay, from the lowest: compound 2; then compounds 1, 4 and 3 (each within the scatter of the next, the first and the last beyond it).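

In this assay this position now has its first direct reading, a 1.3-fold higher number from compound 1 to compound 4 (0.11 log units; within the scatter), so the two compounds cannot be told apart. The change on this aromatic carbon of the five-membered ring is not a minimal one: 2-bromo-6-methoxyphenyl has more heavy atoms than 4-chlorophenyl, and it brings 1 hydrogen-bond acceptor where the leaving group has none, yet the exchange produces no difference beyond the scatter. This holds for this one pair only, and nothing available here explains the result.

As far as these compounds go, a single swap between two substituted phenyl rings says little about groups of a different kind at this position, so it remains open whether a carboxylic acid, an aminomethyl group or a small saturated ring such as cyclopropyl would leave the number just as steady. From the compounds shown here alone, it is also open whether 2-bromo-6-methoxyphenyl would behave the same way on the other chain ends seen here, such as the shorter chain of compound 3 or the isobutyl-bearing ring of compound 2.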